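The source may hold more compounds than are shown below. What is called first, only, known or untested is meant among the compounds shown, and "the series" means these compounds.

Compound 1 `c1ccc(-c2nc(-c3c[nH]c4ccccc34)co2)cc1` and compound 2 `Clc1ccc(-c2nc(-c3c[nH]c4ccccc34)co2)cc1` share one core and differ only by a substituent on an aromatic carbon. In a functional assay on PC-3 cells (Homo sapiens) for cytotoxicity, read by MTT assay, with a stated time of 48 h (a higher number here means a weaker inhibitor, a lower number a stronger inhibitor), compound 1 gives 170000 nM, while compound 2 gives 151000 nM. Of these two numbers compound 1 holds the higher, but the gap is small: a 1.1-fold lower number from compound 1 to compound 2 (0.05 log units; within the scatter). Compound 3 `COc1ccc(-c2nc(-c3c[nH]c4ccccc34)co2)cc1` carries a different substituent at that kind of position: methoxy in place of hydrogen on an aromatic carbon. Only the chloro step bears on this change, and it stayed within the scatter, so no step beyond the scatter is expected in this assay. Compound 3 is therefore estimated at 150000 nM, between 60000 nM and 400000 nM, which means an expected step of a 1.1-fold lower number from compound 1 to compound 3 (0.05 log units; within the scatter).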

Compound 3, half-maximal inhibitory concentration: 133000 nM
Compound 3: the middle estimate sits 1.1-fold (0.05 log units) above what was measured, within the range that was stated.
By their numbers in this assay, from the lowest: compounds 3, 2 and 1 (each within the scatter of the next).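

In this assay, methoxy on this aromatic carbon, para to a large group, stays within the scatter of hydrogen (a 1.3-fold lower number from compound 1 to compound 3 (0.11 log units; within the scatter)), as chloro did. Replacing chloro directly with methoxy also stays within the scatter (a 1.1-fold lower number from compound 2 to compound 3 (0.06 log units; within the scatter)), so two different groups at this position now give no readable difference from hydrogen or from each other. Nothing available here offers an explanation for this result. From the compounds shown here alone, whether an amine, a carboxylic acid or a longer chain at this position would produce a step beyond the scatter remains open. So does the effect of changes elsewhere on the shared core.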